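The source may hold more compounds than are shown below. What is called first, only, known or untested is meant among the compounds shown, and "the series" means these compounds.

In a functional assay on Jurkat cells (Homo sapiens) (on this read-out lower numbers stand for stronger inhibition and higher numbers for weaker inhibition), compound 1 `CC(C)[C@H](NC(=O)COc1cccc2ccccc12)C(=O)N[C@@H](CC(=O)O)C(=O)COc1ccc(-c2ccccc2)cc1` gives 87900 nM. Compound 2 `CC(C)[C@H](NC(=O)COc1cccc2ccccc12)C(=O)N[C@@H](CC(=O)O)C(=O)COc1ccccc1C(F)(F)F` gives > 100000 nM, which is a limit of the assay and not a number. Within the data shown here, compound 3 `CC(C)[C@H](NC(=O)COc1cccc2ccccc12)C(=O)N[C@@H](CC(=O)O)C(=O)COc1ccc(Oc2ccc(C(F)(F)F)cc2)cc1` gives 9300 nM, the lower of the two actual numbers so far. Compound 4 `CC(C)[C@H](NC(=O)COc1cccc2ccccc12)C(=O)N[C@@H](CC(=O)O)C(=O)COc1ccc(F)cc1` is still to be measured. The change from compound 3 is fluoro in place of 4-(trifluoromethyl)phenoxy on an aromatic carbon, para to a large group.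

Among the measured compounds shown here, two measured steps bear on this. The closer one is a 9.5-fold lower number from compound 1 to compound 3 (0.98 log units; beyond the scatter), where 4-(trifluoromethyl)phenoxy came in place of phenyl on an aromatic carbon. Compound 4 gives up that same group. The other is an at least 1.1-fold higher number from compound 1 to compound 2 (0.05 log units; that floor lies within the scatter), with 2-(trifluoromethyl)phenyl in place of 4-phenylphenyl. It offers only a floor and sets no size. A step close in size to the first one is therefore expected in this assay, towards a higher number, and compound 4 may well return only a limit. For compound 4 the estimate is 70000 nM, with an expected range from 25000 nM to 150000 nM. That is an estimated 7.5-fold higher number from compound 3 to compound 4 (0.88 log units; beyond the scatter).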

Compound 4, half-maximal inhibitory concentration: > 100000 nM
Compound 4: a limit, no number; the forecaster's own chance of this, stated with the estimate: 40%; middle value at least 1.4-fold (0.15 log units) from the limit.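

In this assay, fluoro in place of 4-(trifluoromethyl)phenoxy on an aromatic carbon, para to a large group, gives an at least 10-fold higher number from compound 3 to compound 4 (1.03 log units; beyond the scatter), so at this position the loss of the whole 4-(trifluoromethyl)phenoxy group takes the series from a number to a limit. Fluoro in place of phenyl at the same position gives an at least 1.1-fold higher number from compound 1 to compound 4 (0.05 log units; that floor lies within the scatter), a floor that lies within the scatter, so compound 4 cannot be ranked against compound 1 and, of the groups at this position, only 4-(trifluoromethyl)phenoxy stands clearly apart. The step between compound 2 and compound 4 cannot be read, as both values are limits and no order between them follows: the limit of > 100000 nM in this assay, at which 2 of the 4 values shown sit.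

As far as these compounds go, whether the lower number of compound 3 rests on the trifluoromethyl group, on the ether oxygen or on the second ring alone remains open, and a plain phenoxy or a benzyloxy group at this position would begin to separate these. Also open, from the compounds shown here alone, is whether a small amine or a carboxylic acid on this aromatic carbon would return a number or another limit.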